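The compounds below may be only part of what the source reports. "The series", "measured", "known", "first", "only" and "open" are said of these compounds alone.

Values measured in a functional assay on HFF cells (Homo sapiens) for cytotoxicity; a higher number here means a weaker inhibitor, a lower number a stronger inhibitor:
- compound 1 `CC(=O)OC1C(CF)OC(n2c(Cl)nc3cc(Cl)c(Cl)cc32)C1OC(C)=O`: 32000 nM
- compound 2 `CC(=O)OC1C(CCl)OC(n2c(Cl)nc3cc(Cl)c(Cl)cc32)C1OC(C)=O`: 32000 nM
- compound 3 `CCCCOC[C@H]1OC(n2c(Cl)nc3cc(Cl)c(Cl)cc32)[C@H](O)[C@@H]1O`: 32000 nM

Compound 3 stands level with compound 1 and compound 2 on these numbers. The next molecule, compound 4 `CSC[C@H]1OC(n2c(Cl)nc3cc(Cl)c(Cl)cc32)[C@H](O)[C@@H]1O`, keeps the shared core and exchanges one group: methylsulfanyl in place of butoxy on a saturated chain carbon bound to a saturated ring carbon, (methylsulfanyl in place of butoxy on a saturated chain carbon bound to a saturated ring carbon). Among the compounds with values here, only one measured step touches that kind of place, chloro in place of fluoro: no change at the digits printed from compound 1 to compound 2 (within the scatter). That swap is much smaller, so it is weak guidance. Even so, with that step as the only guide, no change beyond the scatter is expected in this assay, and no direction is favoured. The expected step is no change at the digits printed from compound 3 to compound 4 (within the scatter). The estimate for compound 4 is 32000 nM, with an expected range of 12000 nM to 64000 nM.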

Compound 4, half-maximal inhibitory concentration: 32000 nM
Compound 4: middle estimate and measured number agree at the digits printed, within the range that was stated.
By their numbers in this assay, from the lowest: compounds 1, 2, 3 and 4 (each within the scatter of the next).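

In this assay, replacing butoxy with methylsulfanyl on a saturated chain carbon bound to a saturated ring carbon gives no change at the digits printed from compound 3 to compound 4 (within the scatter). The earlier chloro-for-fluoro swap was a small one, whereas this exchange is much larger, removing the butoxy chain and bringing in sulfur, and the number still holds. No measurement shown here explains this flat result.

From the compounds shown here alone, whether an amine or a carboxylic acid at this place, or a chain longer than butoxy, would shift the number remains open.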